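The source may report more compounds than this note shows. Statements on the series, on what has been measured and on what is new or still open speak of the compounds shown alone.

Compound 1 `C=CC(=C)CC[C@@H]1[C@@]2(C)CCC[C@](C)(COC(=O)/C=C\c3ccc(O)cc3)[C@@H]2CC[C@@]1(C)O` — 16200 nM
Compound 2 `C=C[C@@]1(C)O[C@H]1C[C@H]1C(=C)CC[C@@H]2[C@]1(C)CCC[C@]2(C)C(=O)O` — > 40000 nM

Both compounds were tested in a functional assay on SMMC-7721 cells (Homo sapiens) for cytotoxicity, read by MTT assay, with a stated time of 48 h; a higher number here means a weaker inhibitor, a lower number a stronger inhibitor. Compound 1 gives a measured number, 16200 nM. Compound 2 gives only a limit, > 40000 nM, so its true position is not pinned down. Compound 2 sits at the limit of > 40000 nM in this assay, at which 1 of the 2 values shown sits. The step from compound 2 to compound 3 `C=C[C@@](C)(O)CC[C@H]1C(=C)CC[C@@H]2[C@]1(C)CCC[C@]2(C)C(=O)O` is a single exchange: a group of 6 heavy atoms (5 carbon, 1 oxygen; no ring) in place of a group of 6 heavy atoms (5 carbon, 1 oxygen; one three-membered non-aromatic ring with 1 hetero atom), on a saturated chain carbon bound to a saturated ring carbon. The three-membered ring with one hetero atom leaves, and a 2-hydroxy-2-methylbut-3-en-1-yl group enters on a saturated chain carbon bound to a saturated ring carbon; the rest of the shared core is unchanged. Among the measured compounds shown here, no measured step between compounds is available to gauge this change. The step that the limit leaves unreadable from compound 2 to compound 3 is therefore expected to be small, in no particular direction, and not beyond the scatter. Compound 3 is expected to give about 45000 nM in this assay, within 15000 nM to 120000 nM, and quite possibly to be reported only as a limit.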

Compound 3, half-maximal inhibitory concentration: > 40000 nM
Compound 3 was reported as a limit; the forecaster's own chance of this, stated with the estimate: 60%; the middle value is on the limit's open side.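

Compound 2 and compound 3 are both reported only as limits in this assay, so no step between them can be read: the limit of > 40000 nM in this assay, at which 2 of the 3 values shown sit.

The compounds shown leave open whether the 2-hydroxy-2-methylbut-3-en-1-yl group in compound 3 changes the cytotoxicity of compound 2 at all, and in which direction.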